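A few compounds are considered here, and "the series" means these few. Any claim that something is new, unique, unknown or untested is made for them only; others in the source may bear on it.

Measured in a functional assay on MDA-MB-231 cells (Homo sapiens) for inhibition, read by colorimetric assay and sulforhodamine B assay, with a stated time of 48 h; on this read-out higher numbers stand for weaker inhibition of growth and lower numbers for stronger inhibition of growth:
compound 1 `CCCCCCCCCCCC[C@@H](O)[C@H]1CC[C@H]([C@H](O)CCCCCCCCCCNC(=O)c2cccs2)O1`: 2570 nM
compound 2 `CCCCCCCCCCCC[C@@H](O)[C@H]1CC[C@H]([C@H](O)CCCCCCCCCCNC(=O)c2ccco2)O1`: 100000 nM
Not yet measured: compound 3 `CCCCCCCCCCCC[C@@H](O)[C@H]1CC[C@H]([C@H](O)CCCCCCCCCCNC(=O)c2ccoc2)O1`

For the measured compounds named here, of the two numbers so far, compound 2 has the higher, 100000 nM, making it the weaker growth inhibitor of the pair. Compound 3 differs from it in one place: furan-3-yl in place of furan-2-yl on a carbonyl carbon. Going by the values given here, only one measured step bears on this change: a 39-fold higher number from compound 1 to compound 2 (1.59 log units; beyond the scatter). That large step shows that this assay can respond strongly to a change in the group on this carbonyl carbon. However, that step replaced one ring with another, and no measured pair yet shows a change in how the same atoms are joined. Compound 1, at 2570 nM, shows that numbers far lower than that of compound 2 are reachable, so a moderate move downward is expected. The expected change is a 4.0-fold lower number from compound 2 to compound 3 (0.60 log units; beyond the scatter), and it is uncertain. For compound 3, the estimated value is 25000 nM, with an expected range of 4000 nM to 100000 nM.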

Compound 3, concentration for 50% growth inhibition: 100000 nM
The estimate for compound 3 lay 4.0-fold (0.60 log units) below the measured number; the range from low to high includes it.
By their numbers in this assay, from the lowest: compound 1; then compounds 2 and 3 (each within the scatter of the next).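

In this assay, furan-3-yl in place of furan-2-yl on the carbonyl carbon gives no change at the digits printed from compound 2 to compound 3 (within the scatter), so joining the same ring atoms differently changes nothing that this read-out can detect. Furan-3-yl in place of thiophen-2-yl gives a 39-fold higher number from compound 1 to compound 3 (1.59 log units; beyond the scatter), which shows that the large gap seen with the first furan also appears with the second, leaving compound 1 the strongest growth inhibitor of the three. No measurement shown here explains why the thiophen-2-yl compound differs from the two furan compounds.

Going by these compounds, it remains open whether thiophen-3-yl would keep the activity of thiophen-2-yl, which would show whether the way the ring is joined matters for a sulfur-containing ring. A phenyl or pyridinyl ring on the same carbonyl carbon would show whether thiophen-2-yl is unusual among aromatic rings.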